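The source may hold more compounds than are shown below. What is called first, only, known or untested is meant among the compounds shown, and "the series" means these compounds.

Compound 1 `O=S(=O)(Nc1ccc(-c2nc3cc(NS(=O)(=O)c4ccccc4)ccc3o2)cc1)c1ccccc1`: 30000 nM
Compound 2 `COc1ccc(S(=O)(=O)Nc2ccc(-c3nc4cc(NS(=O)(=O)c5ccc(OC)cc5)ccc4o3)cc2)cc1`: 57000 nM

Both compounds were tested in an ADME assay on FHC cells (Homo sapiens) for cytotoxicity, read by resazurin assay, with a stated time of 48 h; on this read-out lower numbers stand for higher toxicity in this test and higher numbers for lower toxicity in this test. There compound 2 gives 57000 nM and compound 1 gives 30000 nM, and these two numbers lie within the scatter of each other. Among the compounds with values here, compound 2 therefore stands level with the only other compound measured so far.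

Compound 3 `COc1ccc(S(=O)(=O)Nc2ccc3oc(-c4ccc(NC(=O)c5cccc(C)c5[N+](=O)[O-])cc4)nc3c2)cc1` has not yet been measured. It carries (3-methyl-2-nitrophenyl)carbonyl in place of (4-methoxyphenyl)sulfonyl on a nitrogen on an aromatic ring. Within the data shown here, the measured pair differs in more than one place, so the data hold no single-change step to serve as a guide, and nothing shows how this particular exchange behaves. Still, with compound 1 at 30000 nM and compound 2 at 57000 nM, the two values give no sign of a large swing. No step beyond the scatter is therefore expected in this assay, in either direction. The expected change is a 1.4-fold lower number from compound 2 to compound 3 (0.15 log units; within the scatter). For compound 3 the estimated value is 40000 nM, with an expected range from 13000 nM to 110000 nM.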

Compound 3, half-maximal cytotoxic concentration: > 100000 nM
Compound 3: no number, only a limit; the forecaster's own chance of this, stated with the estimate: 20%; middle value at least 2.5-fold (0.39 log units) from the limit.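

Placing (3-methyl-2-nitrophenyl)carbonyl in place of (4-methoxyphenyl)sulfonyl on a nitrogen on an aromatic ring gives the only single-place step available in this assay, an at least 1.7-fold higher number from compound 2 to compound 3 (0.24 log units; that floor lies within the scatter). Compound 3 is recorded only as a limit, > 100000 nM, in this assay, so the step gives a floor and its true size cannot be read because the assay reports no number for compound 3: the limit of > 100000 nM in this assay, at which 1 of the 3 values shown sits. Even so, this nitrogen accepts the carbonyl-linked ring in place of the sulfonyl-linked ring with no sign of a lower number in this test, which compound 1 and compound 2 could not show, since they differ from each other in more than one place.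

The exchange alters the linking group and the ring substituents at once, so the data do not tell whether the carbonyl, the nitro group or the methyl group accounts for the result. Going by these compounds, it also remains open how a smaller acetyl group, or a ring carrying an amine or a carboxylic acid in place of the nitro group, would behave on this nitrogen.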